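Swapping Isopropyl for Propyl on a Carbamate Ester

The compounds below may be only part of what the source reports. "The series", "measured", "known", "first", "only" and "open" are said of these compounds alone.

Compound 1 `CCc1cc(S(=O)(=O)N2C[C@H](c3ccccc3)NC2=O)ccc1NC(=O)OC(C)C` gives 60 nM in a functional assay on A549 cells (Homo sapiens) for cytotoxicity, read by MTT assay; on this read-out lower numbers stand for stronger inhibition and higher numbers for weaker inhibition.
Compound 2 `CCOC(=O)Nc1c(C)cc(S(=O)(=O)N2C[C@H](c3ccccc3)NC2=O)cc1C` gives > 10000 nM in this assay, which is a limit of the assay and not a number.
Compound 3 `CCOC(=O)Nc1ccc(S(=O)(=O)N2C(=O)N[C@@H](c3ccccc3)C2C)cc1C` gives 5000 nM in this assay.

Among the two numbers actually measured, compound 1 has the lowest, so it is the strongest inhibitor of cell growth in this set; compound 3 sits higher, and that gap lies beyond the usual scatter of repeat measurements. For compound 2 the assay reports only its upper limit (the limit of > 10000 nM in this assay, at which 1 of the 3 values shown sits).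

Compound 4 `CCCOC(=O)Nc1ccc(S(=O)(=O)N2C[C@H](c3ccccc3)NC2=O)cc1CC` differs from compound 1 in one place only: propyl in place of isopropyl on an oxygen next to a carbonyl group. No two of the measured compounds differ from each other in just one place, so nothing measured here shows directly what such a change does. The expected step from compound 1 to compound 4 is no change at the digits printed from compound 1 to compound 4 (within the scatter), meaning no change beyond the scatter. Compound 4 is therefore estimated at 60 nM, within a range of 20 nM to 200 nM.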

Compound 4, half-maximal inhibitory concentration: 60 nM
For compound 4 middle estimate and measured number coincide at the digits printed; measured number inside the range.
By their numbers in this assay, from the lowest: compounds 1 and 4 (each within the scatter of the next); then compound 3. At a limit, above all of these: compound 2.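

In this assay, going by these compounds alone, the swap of isopropyl for propyl gives no change at the digits printed from compound 1 to compound 4 (within the scatter), and this is the first pair in the set that differs in one place only. On this oxygen next to a carbonyl group, then, the two chains, which have the same count of heavy atoms, cannot be told apart by this read-out, at least on the core of compound 1. The earlier compounds shown here could not show this, as each of them differs from the others in more than one place.

The data shown give no reason why the two chains match. Going by these compounds, it also stays open whether a longer chain such as butyl, a benzyl group or a chain ending in an amine or a carboxylic acid would keep the number at this place, and whether the same swap would read alike on a different core.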